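This account rests on a few compounds, and the source may have more. Where it says the series, first, only, none or still open, it means among the compounds named here.

Compound 1 `COc1cc(/C=C/c2ccc3ccccc3c2)cc([N+](=O)[O-])c1OC`: 3200 nM
Compound 2 `COc1cc(/C=C/c2ccc3ccccc3c2)cc(N)c1OC`: 460 nM

In a functional assay on HeLa cells (Homo sapiens) for inhibition (on this read-out lower numbers stand for stronger inhibition and higher numbers for weaker inhibition), compound 2 has the lower of the two numbers, and the gap to compound 1 lies beyond the scatter. Compound 3 `COc1cc(/C=C/c2ccc3ccccc3c2)cc(NC(C)=O)c1OC` differs from compound 2 in one place: acetyl in place of hydrogen on a nitrogen on an aromatic ring. This is acetyl in place of hydrogen on a nitrogen on an aromatic ring, which turns amino to acetamido. Among the measured compounds shown here, only one measured step bears on this: a 7.0-fold lower number from compound 1 to compound 2 (0.84 log units; beyond the scatter), a modest change that came with amino in place of nitro on an aromatic carbon. For the measured compounds named here, it shows that the group at this place can move the number, but no measured compound carries an acetyl, so the evidence is thin. Compound 1, without the amino group, sits higher at 3200 nM, so a modest rise in this assay is expected, similar to or smaller than that step. The expected change is a 2.6-fold higher number from compound 2 to compound 3 (0.42 log units; beyond the scatter). For compound 3 the estimated value is 1200 nM, with an expected range from 280 nM to 5000 nM.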

Compound 3, half-maximal inhibitory concentration: > 5000 nM
Compound 3 was reported as a limit; the forecaster's own chance of this, stated with the estimate: 5%; middle value at least 4.1-fold (0.61 log units) away from the limit.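

In this assay, compound 3 gives a limit and not a number: the limit of > 5000 nM in this assay, at which 1 of the 3 values shown sits. Even so, the step is large, an at least 10-fold higher number from compound 2 to compound 3 (1.03 log units; beyond the scatter), which shows that this nitrogen is sensitive to what it carries: the earlier pair showed only that amino and nitro differ, and now an acetyl on the amino group loses at least all of that gain. The step for acetamido in place of nitro is an at least 1.5-fold higher number from compound 1 to compound 3 (0.19 log units; that floor lies within the scatter), and as that floor lies within the scatter, replacing nitro does not by itself lower the number; among these three groups, only amino does.

On these data alone, how far beyond its limit compound 3 lies stays open. As far as these compounds go, it is also open how a smaller change on this nitrogen, such as a methylamino or dimethylamino group, or a hydroxyl group in place of the amino group, would read.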